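This account rests on a few compounds, and the source may have more. Where it says the series, first, only, none or still open, it means among the compounds named here.

Measured in a functional assay on MGC-803 cells (Homo sapiens) for antiproliferative activity, read by MTT assay; a lower number here means a stronger inhibitor, a higher number a weaker inhibitor:
- compound 2 `COc1ccccc1NC(=O)Nc1cccc(CNc2ncnc3cc(OC)c(OC)cc23)c1`: 7710 nM
- compound 1 `Cc1cccc(NC(=O)Nc2cccc(CNc3ncnc4ccccc34)c2)c1`: 30200 nM

Compound 2 holds the lower of the two numbers in this assay; compound 1 sits higher by a gap that lies beyond the usual scatter. Compound 3 `COc1cc2ncnc(NCc3cccc(NC(=O)Nc4ccc(F)cc4)c3)c2cc1OC` has not been measured. It differs from compound 2 only in 4-fluorophenyl in place of 2-methoxyphenyl on an amide-type nitrogen. For the measured compounds named here, no measured pair shows this change, so its effect is not fixed by the data; a step of modest size in either direction, or none beyond the scatter, is what is expected. Compound 3 is estimated at 10000 nM, with a range from 3500 nM to 30000 nM, which means an expected step of a 1.3-fold higher number from compound 2 to compound 3 (0.11 log units; within the scatter).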

Compound 3, half-maximal inhibitory concentration: 42100 nM
Compound 3: middle estimate off by 4.2-fold (0.62 log units), on the low side; the measured number lies above the stated range.
By their numbers in this assay, from the lowest: compound 2; then compounds 1 and 3 (each within the scatter of the next).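

In this assay, the group on this amide-type nitrogen matters: 4-fluorophenyl in place of 2-methoxyphenyl gives a 5.5-fold higher number from compound 2 to compound 3 (0.74 log units; beyond the scatter) on an otherwise unchanged compound. For the compounds shown here, this is the first single-place step, and it favours the 2-methoxyphenyl group at this position. No measurement on hand explains this step.

Methoxy and fluorine change together here, so the compounds shown do not separate their contributions. From the compounds shown here alone, whether a plain phenyl or a cyclohexyl on the same nitrogen would stand nearer compound 2 or compound 3 remains open.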